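Ester Amide Replaces the Carbamoylethyl Chain on the Amine

The source may hold more compounds than are shown below. What is called first, only, known or untested is meant among the compounds shown, and "the series" means these compounds.

Compound 3 `Cc1cn([C@@H]2O[C@H](CO[Si](C)(C)C(C)(C)C)[C@@]3(OS(=O)(=O)C=C3NCCC(N)=O)[C@H]2O[Si](C)(C)C(C)(C)C)c(=O)n(C)c1=O` is known in a functional assay on HEL cells (Homo sapiens) for cytotoxicity, read by microscopy (a higher number here means that more compound is tolerated, a lower number that less compound is tolerated), only as a limit, >= 80000 nM. Compound 1 `CCOC(=O)NC(=O)NC1=CS(=O)(=O)O[C@@]12[C@@H](CO[Si](C)(C)C(C)(C)C)O[C@@H](n1cc(C)c(=O)n(C)c1=O)[C@@H]2O[Si](C)(C)C(C)(C)C` gives 16000 nM in this assay. Compound 2 `COC(=O)C(=O)CNC1=CS(=O)(=O)O[C@@]12[C@@H](CO[Si](C)(C)C(C)(C)C)O[C@@H](n1cc(C)c(=O)n(C)c1=O)[C@@H]2O[Si](C)(C)C(C)(C)C` reaches only a limit there, > 400000 nM. The measured steps read an at least 25-fold higher number from compound 1 to compound 2 (1.39 log units; beyond the scatter) and an at least 5.0-fold higher number from compound 1 to compound 3 (0.69 log units; beyond the scatter), while a step that the two limits leave unreadable from compound 2 to compound 3. Compound 4 `COC(=O)CC(=O)NC1=CS(=O)(=O)O[C@@]12[C@@H](CO[Si](C)(C)C(C)(C)C)O[C@@H](n1cc(C)c(=O)n(C)c1=O)[C@@H]2O[Si](C)(C)C(C)(C)C` differs from compound 3 by ((methoxycarbonyl)methyl)carbonyl in place of 2-carbamoylethyl on an amine nitrogen. Compound 1 also carries a carbonyl group directly on that amine nitrogen and is the least tolerated of the three, so the step of an at least 5.0-fold higher number from compound 1 to compound 3 (0.69 log units; beyond the scatter) bears on this change, read in reverse. A smaller number than the limit of compound 3 is therefore expected for compound 4, an at least 2.6-fold lower number from compound 3 to compound 4 (0.42 log units; beyond the scatter). Compound 4 is estimated at 30000 nM, between 10000 nM and 120000 nM.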

Compound 4, minimum cytotoxic concentration: 400000 nM
Beside the measured number, compound 4's estimate is 13-fold (1.12 log units) below it; the whole stated range lies below it.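

Placing (methoxycarbonyl)methyl in place of (ethoxycarbonyl)amino on a carbonyl carbon gives a 25-fold higher number from compound 1 to compound 4 (1.40 log units; beyond the scatter) in this assay. A carbonyl group directly on the amine nitrogen therefore does not by itself go with low tolerance, and among the compounds shown the low number goes only with compound 1, the one compound carrying (ethoxycarbonyl)amino. Placing ((methoxycarbonyl)methyl)carbonyl in place of ((methoxycarbonyl)carbonyl)methyl on an amine nitrogen gives a number no higher from compound 2 to compound 4 (the limit leaves the size open) in this assay. The step to compound 4 from compound 3 cannot be read.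

From the compounds shown here alone, whether an amine or a carboxylic acid on that carbonyl carbon would keep the number of compound 4 stays open. So does the effect of a longer chain there.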